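Replacing a silyl ether by an acetate on a shared core

The source may report more compounds than this note shows. Statements on the series, on what has been measured and on what is new or still open speak of the compounds shown alone.

Two compounds of the same core were examined in a functional assay on P388 cells (Mus musculus) for cytotoxicity, read by sulforhodamine B assay; on this read-out lower numbers stand for an effect already at smaller amounts and higher numbers for an effect only at larger amounts of compound. Compound 1 `C=C1CC[C@@H]2[C@](C)(CO[Si](C(C)C)(C(C)C)C(C)C)[C@H](O)CC[C@@]2(C)[C@@H]1C/C=C1/C(=O)OC[C@H]1O` carries a silyl ether on the side-chain oxygen, and in this assay compound 1 gives 0.88 uM. Compound 2 `C=C1CC[C@@H]2[C@](C)(COC(c3ccccc3)(c3ccccc3)c3ccccc3)[C@H](O)CC[C@@]2(C)[C@@H]1C/C=C1/C(=O)OC[C@H]1O` carries a trityl ether at the same oxygen, and in this assay compound 2 gives 0.45 uM. Compound 1 thus stands at the higher of the two numbers, but its gap to compound 2 lies within the usual scatter, so the two values cannot be told apart.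

Compound 3 `C=C1CC[C@@H]2[C@](C)(COC(C)=O)[C@H](O)CC[C@@]2(C)[C@@H]1C/C=C1/C(=O)OC[C@H]1O` has not yet been measured in this assay. It differs from compound 1 in one place: a group of 3 heavy atoms (2 carbon, 1 oxygen; no ring) in place of a group of 10 heavy atoms (9 carbon, 1 silicon; no ring), on an oxygen on a saturated carbon. Among the measured compounds shown here, no measured step of this kind is available for comparison, so the expectation rests only on compound 1 at 0.88 uM and compound 2 at 0.45 uM, two quite different groups at this oxygen that gave values within the scatter of each other. The estimated step of a 1.7-fold higher number from compound 1 to compound 3 (0.23 log units; within the scatter) is therefore expected to be small, if anything toward a slightly higher number. Compound 3 is expected to give about 1.5 uM, with a range from 0.4 uM to 6 uM.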

Compound 3, concentration for half-maximal effect: 2.04 uM
Estimate against measurement, compound 3: 1.4-fold (0.13 log units) below; measured number inside the range.
By their numbers in this assay, from the lowest: compounds 2 and 1 (each within the scatter of the next); then compound 3.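

In this assay the oxygen on a saturated carbon now shows that its substituent can matter: the acetyl in place of the silyl ether gives a 2.3-fold higher number from compound 1 to compound 3 (0.37 log units; beyond the scatter) as a modest step, whereas the silyl ether of compound 1 and the trityl ether of compound 2 had stayed within the scatter of each other. The effect of this exchange is limited, since compound 3 still gives 2.04 uM in the same low range, so a group of 10 heavy atoms on this oxygen is not required for a micromolar number. Nothing available explains the step.

The compounds shown leave open whether the step follows the change from ether to ester or the smaller group, and a methyl ether or a benzoate ester on the same oxygen would help separate these two readings. They also leave open how the free hydroxyl, with no group on this oxygen, or an amine carried on a longer chain there, would stand against compound 1 and compound 3 on this read-out.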